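Trimming the Piperidine Cap: Expected Permeability of Compound 4

A few compounds are considered here, and "the series" means these few. Any claim that something is new, unique, unknown or untested is made for them only; others in the source may bear on it.

In an ADME assay on Caco-2 cells (Homo sapiens) for permeability, in the apical to basolateral direction (a higher number here means that the compound crosses the layer faster, a lower number that the compound crosses the layer more slowly), compound 1 `Cn1cncc1CN1CC(N(CCn2cccc2)S(=O)(=O)c2ccccn2)Cc2cc(C#N)ccc21` gives 12.4 10^-6 cm/s, compound 2 `Cn1cncc1CN1CC(N(CC2CCN(C(=O)c3ccccc3)CC2)S(=O)(=O)c2ccccn2)Cc2cc(C#N)ccc21` gives 0.5 10^-6 cm/s, and compound 3 `Cn1cncc1CN1CC(N(CC2CCN(C(=O)OCc3ccccc3)CC2)S(=O)(=O)c2ccccn2)Cc2cc(C#N)ccc21` gives 1 10^-6 cm/s. Compound 3 thus stands second highest of the three: its number lies within the scatter of compound 2, while its gap to compound 1 is beyond the scatter. Among the measured compounds shown here, the only measured change at the carbonyl carbon is the step of a 2.0-fold higher number from compound 2 to compound 3 (0.30 log units; within the scatter), which stayed within the scatter. Compound 4 `CC(C)C(=O)N1CCC(CN(C2Cc3cc(C#N)ccc3N(Cc3cncn3C)C2)S(=O)(=O)c2ccccn2)CC1` differs from compound 3 by isopropyl in place of benzyloxy on a carbonyl carbon. For the measured compounds named here, with that single small step as the only guide, no move beyond the scatter is expected in this assay, though a modest rise seems plausible. The estimate for compound 4 is therefore 1.6 10^-6 cm/s, with a range from 0.5 10^-6 cm/s to 5 10^-6 cm/s, an expected step of a 1.6-fold higher number from compound 3 to compound 4 (0.20 log units; within the scatter).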

Compound 4, apparent permeability: 0.5 10^-6 cm/s
Compound 4: the middle estimate sits 3.2-fold (0.51 log units) above what was measured; low and high end bracket the measured number.
By their numbers in this assay, from the lowest: compounds 2, 4 and 3 (each within the scatter of the next); then compound 1.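

At this carbonyl carbon, isopropyl in place of benzyloxy gives (a 2.0-fold lower number from compound 3 to compound 4 (0.30 log units; within the scatter)) and isopropyl in place of phenyl gives (no change at the digits printed from compound 2 to compound 4 (within the scatter)), so in this assay a cap with no aromatic ring stays within the scatter of the two caps that carry one. The large gap lies elsewhere, with 1-(isopropylcarbonyl)piperidin-4-yl in place of (1H-pyrrol-1-yl)methyl (a 25-fold lower number from compound 1 to compound 4 (1.39 log units; beyond the scatter)). No available measurement explains these numbers. Open, going by these compounds, is whether the piperidine as a free amine, with no carbonyl group, would stay with these three caps or move towards compound 1.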